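This account rests on a few compounds, and the source may have more. Where it says the series, first, only, none or still open, it means among the compounds named here.

Compound 1 `CNc1[nH]c(=O)n(O)c(=O)c1C(=O)NCc1ccccc1` — in an ADME assay on microsomes from liver (Homo sapiens) for metabolic stability (a lower number here means slower removal, a higher number faster removal of the compound), compound 1 gives < 0.1 uL/min, a limit of the assay rather than a number.
Compound 2 `CCNc1[nH]c(=O)n(O)c(=O)c1C(=O)NCc1cccc(Cl)c1F` — in this assay compound 2 gives < 0.1 uL/min, again a limit of the assay.
Compound 3 `CCNc1[nH]c(=O)n(O)c(=O)c1C(=O)NCc1ccc(F)cc1` — in this assay compound 3 gives < 0.1 uL/min, also a limit of the assay.

Compound 2 therefore stands at the floor of what this assay reports, and so does every other value shown (the limit of < 0.1 uL/min in this assay, at which 3 of the 3 values shown sit). Among the compounds with values here, the one measured step that touches the same place on the structure, a step that the two limits leave unreadable from compound 2 to compound 3, is unreadable in size and direction, since both of its ends are limits. The unmeasured compound 4 `CCNc1[nH]c(=O)n(O)c(=O)c1C(=O)NCc1ccc(C)c(F)c1` differs from compound 2 by 3-fluoro-4-methylphenyl in place of 3-chloro-2-fluorophenyl on a saturated chain carbon bound to an amide-type nitrogen. Within the data shown here, with no readable step to draw on, nothing in the data points to a change beyond the scatter in either direction, and every value so far sits at the limit (the limit of < 0.1 uL/min in this assay, at which 3 of the 3 values shown sit). The expected step of a number no lower from compound 2 to compound 4 (the limit leaves the size open) is accordingly estimated as none beyond the scatter, with the result most likely reported again as a limit. Compound 4 is thus estimated to give 0.1 uL/min, with a range from 0.05 uL/min to 0.3 uL/min.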

Compound 4, intrinsic clearance in a liver preparation (reported as CLH), per the amount of preparation that the assay uses: 0.4 uL/min
Estimate against measurement, compound 4: 4.0-fold (0.60 log units) below; measured number outside the range, above it.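

In this assay, the group on a saturated chain carbon bound to an amide-type nitrogen proves able to move the read-out: 3-fluoro-4-methylphenyl in place of 3-chloro-2-fluorophenyl gives an at least 4.0-fold higher number from compound 2 to compound 4 (0.60 log units; beyond the scatter), and in place of 4-fluorophenyl it gives an at least 4.0-fold higher number from compound 3 to compound 4 (0.60 log units; beyond the scatter). Within the data shown here, these are the first steps at this place that can be read, as the step between the two earlier compounds with this ethylamino core has limits at both ends. Compound 4 is the only compound with a number rather than a limit, and the others stay together at the floor: the limit of < 0.1 uL/min in this assay, at which 3 of the 4 values shown sit.

The compounds shown leave open whether the methyl group alone accounts for the step, as no compound here differs from compound 4 in that one feature. They also leave open how a 4-methoxyphenyl or a 4-ethylphenyl group would read at this place.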